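The source may report more compounds than this note shows. Statements on the series, on what has been measured and on what is new or still open speak of the compounds shown alone.

In a functional assay on HUVEC cells (Homo sapiens) for cytotoxicity (on this read-out higher numbers stand for an effect only at larger amounts of compound and lower numbers for an effect already at smaller amounts), compound 3 (`CCc1ccc(/C=C/C(O)=C2/C(=O)C(C)=C(OC)C(C)(C)C2=O)cc1`) stands at "not determined" (no result reported) and so offers no starting number, while compound 1 (`COC1=C(C)C(=O)/C(=C(O)/C=C/c2ccccc2OC)C(=O)C1(C)C`) gives 1.7 ug/mL and compound 2 (`COC1=C(C)C(=O)/C(=C(O)/C=C/c2ccc(O)cc2)C(=O)C1(C)C`) gives 3.8 ug/mL on the same read-out. Compound 4 (`COC1=C(C)C(=O)/C(=C(O)/C=C/c2c(C)cccc2C)C(=O)C1(C)C`) differs from compound 3 by 2,6-dimethylphenyl in place of 4-ethylphenyl on a double-bonded chain carbon bound to a double-bonded chain carbon with 2,6-dimethylphenyl in place of 4-ethylphenyl on a double-bonded chain carbon bound to a double-bonded chain carbon. Going by the values given here, the only measured step at that place is a 2.2-fold higher number from compound 1 to compound 2 (0.35 log units; beyond the scatter) and it is modest. It involves other groups and gives no direction, so only a modest step of either sign is expected in this assay relative to those two compounds. Compound 4 is estimated at 2.5 ug/mL with an expected range from 1 ug/mL to 6.5 ug/mL on this read-out.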

Compound 4, concentration for half-maximal effect: 3 ug/mL
Compound 4: middle estimate off by 1.2-fold (0.08 log units), on the low side; low and high end bracket the measured number.
By their numbers in this assay, from the lowest: compounds 1, 4 and 2 (each within the scatter of the next, the first and the last beyond it).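

In this assay, the 2,6-dimethylphenyl group shows a 1.3-fold lower number from compound 2 to compound 4 (0.10 log units; within the scatter) and a 1.8-fold higher number from compound 1 to compound 4 (0.25 log units; within the scatter), so a group of carbon only sits within the scatter of both the 4-hydroxyphenyl and the 2-methoxyphenyl groups, although those two lie beyond the scatter of each other. Compound 3 has no result, so the change from 4-ethylphenyl itself cannot be read. Nothing available explains this result. From the compounds shown here alone, whether an amine or a carboxylic acid on the phenyl ring, or a longer chain in place of the methyl groups, would move the number beyond the scatter stays open.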